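Lengthening the side chain of compound 2

The compounds below may be only part of what the source reports. "The series", "measured", "known", "first", "only" and "open" are said of these compounds alone.

Measured in a functional assay on HepG2 cells (Homo sapiens) for cytotoxicity, read by MTT assay; a higher number here means a weaker inhibitor, a lower number a stronger inhibitor:
compound 1 `COc1cc(CCCCC(C)(C)O)oc(=O)c1C`: > 200000 nM
compound 2 `Cc1c(O)cc(CCCC(C)C)oc1=O`: > 200000 nM

Neither entry is a number, and the record so far holds only (the limit of > 200000 nM in this assay, at which 2 of the 2 values shown sit). In this assay compound 2 stands at > 200000 nM, which is a limit. Going by the values given here, no measured step links the two compounds.

The next compound, compound 3 `Cc1c(O)cc(CCCCC(C)[C@H](C)O)oc1=O`, differs from compound 2 by one change 3-hydroxy-2-methylbutyl in place of isopropyl on a saturated chain carbon, three bonds along the chain from an aromatic carbon. Compound 1 also carries a hydroxy group on its side chain and gives > 200000 nM, again a limit.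

In this assay no step beyond the scatter is expected, and a reading at the same limit is the likeliest outcome. The expected step is a number no higher from compound 2 to compound 3 (the limit leaves the size open). For compound 3 the estimated value is 200000 nM, with an expected range of 80000 nM to 400000 nM.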

Compound 3, half-maximal inhibitory concentration: > 200000 nM
Compound 3 gave a limit, no number; the forecaster's own chance of this, stated with the estimate: 80%; the middle value lies on the limit itself.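

Compound 2 and compound 3 both give limits, not numbers, in this assay, so no step between them can be read: the limit of > 200000 nM in this assay, at which 3 of the 3 values shown sit.

Still open, from the compounds shown here alone, is whether any side chain on the shared core gives a measurable value in this assay, and so how 3-hydroxy-2-methylbutyl compares with isopropyl at this place.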